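Taking the Benzyl Group Away from Compound 1

The compounds below may be only part of what the source reports. "The series", "measured", "known", "first", "only" and "open" are said of these compounds alone.

Measured compounds:
compound 1, `N#Cc1ccc(NC(=O)c2cc(Cc3ccccc3)ccc2O)cc1`: 1930 nM
compound 2, `O=C(Nc1cc(C(F)(F)F)cc(C(F)(F)F)c1)c1ccc(Br)cc1O`: 830 nM

Both were tested in a functional assay on KG-1 cells (Homo sapiens) for cytotoxicity, read by luminescence and CellTiter-Glo, with a stated time of 3 days; on this read-out higher numbers stand for weaker inhibition and lower numbers for stronger inhibition. In this assay compound 1 gives 1930 nM, the higher of the two numbers. Compound 2 gives 830 nM, a lower number, and the gap between the two lies beyond the usual scatter, so compound 2 is the stronger inhibitor of the pair. Compound 3, `N#Cc1ccc(NC(=O)c2ccccc2O)cc1`, has not yet been measured. It differs from compound 1 in a single place: hydrogen in place of benzyl on an aromatic carbon. Among the compounds with values here, no step between two measured compounds shows what this change does on its own, since compound 2 differs from compound 1 in several places at once. With the benzyl group gone and only a hydrogen in its stead, the expectation is a moderate step toward a higher number in this assay, meaning weaker inhibition, a 3.1-fold higher number from compound 1 to compound 3 (0.49 log units; beyond the scatter). Compound 3 is therefore expected to give about 6000 nM, with a likely range from 2000 nM to 20000 nM.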

Compound 3, half-maximal inhibitory concentration: 5370 nM
The estimate for compound 3 lay 1.1-fold (0.05 log units) above the measured number; low and high end bracket the measured number.
By their numbers in this assay, from the lowest: compound 2; then compound 1; then compound 3.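

In this assay, putting hydrogen in place of benzyl on the aromatic carbon para to a hydroxy group gives a 2.8-fold higher number from compound 1 to compound 3 (0.44 log units; beyond the scatter), a modest step beyond the scatter. Within the data shown here, this is the first comparison in which only this one position changes, and it shows that the number at this position depends on the group there, with benzyl going along with stronger inhibition than hydrogen. Nothing measured here gives a reason for this step.

On these data alone, with only benzyl and hydrogen compared, it remains open whether a small methyl group, a longer chain such as phenylethyl or an amine at this position would give a number closer to that of compound 1 or of compound 3. As far as these compounds go, it is also open whether benzyl would bring a similar step on a core carrying a different group on the amide nitrogen.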